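A Shorter Branched Side Chain on a Kinase Inhibitor

The source may hold more compounds than are shown below. What is called first, only, known or untested is meant among the compounds shown, and "the series" means these compounds.

Compound 1 `O=C(Nc1cc2cc[nH]c(=O)c2cc1Cl)[C@H]1CCCN1` and compound 2 `CC(C)C[C@H](N)C(=O)Nc1cc2cc[nH]c(=O)c2cc1Cl` share one core and differ only in the group on the carbonyl carbon. In an assay on isolated protein for inhibition of Rho-associated protein kinase 2 (Homo sapiens) (a lower number here means a stronger inhibitor, a higher number a weaker inhibitor), compound 1 gives 130 nM. In this assay compound 2 gives 340 nM, the higher of the two numbers, separated from its neighbour by a 2.6-fold higher number from compound 1 to compound 2 (0.42 log units; beyond the scatter). Compound 3 `CC(C)[C@H](N)C(=O)Nc1cc2cc[nH]c(=O)c2cc1Cl` differs from compound 2 by isopropyl in place of isobutyl on a saturated chain carbon bound to an amine nitrogen and a carbonyl carbon. Within the data shown here, no measured step bears directly on this change; the only known step, a 2.6-fold higher number from compound 1 to compound 2 (0.42 log units; beyond the scatter), swaps a ring for an open chain and is modest. A step of a 1.1-fold lower number from compound 2 to compound 3 (0.03 log units; within the scatter) is therefore expected, within the scatter. Compound 3 is estimated at 320 nM, with a range from 130 nM to 800 nM.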

Compound 3, half-maximal inhibitory concentration: 12 nM
Compound 3: the middle estimate sits 27-fold (1.43 log units) above what was measured, and the stated range ends above it.
By their numbers in this assay, from the lowest: compound 3; then compound 1; then compound 2.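

Putting isopropyl in place of isobutyl on this saturated chain carbon gives a 28-fold lower number from compound 2 to compound 3 (1.45 log units; beyond the scatter) and shows that this position can respond strongly to the loss of a single carbon. Replacing pyrrolidin-2-yl with an open chain can also go either way: it gives an 11-fold lower number from compound 1 to compound 3 (1.03 log units; beyond the scatter) with 1-amino-2-methylpropyl but a 2.6-fold higher number from compound 1 to compound 2 (0.42 log units; beyond the scatter) with 1-amino-3-methylbutyl. No evidence is available to explain the size of this effect. Still open, from the compounds shown here alone, is how methyl, tert-butyl or cyclopropyl would fare on that same carbon, and what a hydroxyl group would do in place of the amine.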